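Cyano in place of methyl on the benzyloxy arm

The source may report more compounds than this note shows. Statements on the series, on what has been measured and on what is new or still open speak of the compounds shown alone.

Measured in a functional assay on B16 cells (Mus musculus) for cytotoxicity, read by MTT assay, with a stated time of 72 h; on this read-out higher numbers stand for weaker inhibition and lower numbers for stronger inhibition:
compound 1 `COc1c(OCCCCN2CCN(C)CC2)cc(O)c2c(=O)cc(-c3ccc(C)cc3)oc12` gives 5430 nM
compound 2 `CN1CCN(CCCCOc2c(OCc3ccccc3)cc(O)c3c(=O)cc(-c4ccccc4)oc23)CC1` gives 2370 nM
compound 3 `Cc1ccc(COc2cc(O)c3c(=O)cc(-c4ccccc4)oc3c2OCCCCN2CCN(C)CC2)cc1` gives 3290 nM

Compound 3 stands second highest of the three numbers; its gaps to compound 2 and to compound 1 both lie within the scatter. Among the measured compounds shown here, the one single-change step measured so far, a 1.4-fold higher number from compound 2 to compound 3 (0.14 log units; within the scatter), was within the scatter.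

Compound 4 `CN1CCN(CCCCOc2c(OCc3ccc(C#N)cc3)cc(O)c3c(=O)cc(-c4ccccc4)oc23)CC1` differs from compound 3 by cyano in place of methyl on an aromatic carbon. For the measured compounds named here, no measured step covers cyano in place of methyl, so the expectation rests on the small step seen with a 1.4-fold higher number from compound 2 to compound 3 (0.14 log units; within the scatter) on the same aromatic carbon. In this assay the change is therefore expected to give no step beyond the scatter, a 1.0-fold higher number from compound 3 to compound 4 (0.00 log units; within the scatter). Compound 4 is estimated at 3300 nM, with a range from 1400 nM to 8000 nM.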

Compound 4, half-maximal inhibitory concentration: 3700 nM
For compound 4 the middle estimate is 1.1-fold (0.05 log units) below the measured one; measured number inside the range.
By their numbers in this assay, from the lowest: compounds 2, 3, 4 and 1 (each within the scatter of the next, the first and the last beyond it).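

In this assay, cyano in place of methyl gives a 1.1-fold higher number from compound 3 to compound 4 (0.05 log units; within the scatter) and cyano in place of hydrogen gives a 1.6-fold higher number from compound 2 to compound 4 (0.19 log units; within the scatter) on the same aromatic carbon. This carbon, para to a large group, has now carried hydrogen, methyl and cyano, including a group with a hydrogen-bond acceptor, with no step beyond the scatter. Nothing measured bears on why these steps stay small.

Going by these compounds, whether an amine, a carboxylic acid or a methoxy group on this carbon would give a step beyond the scatter remains open. Also open, on these data alone, is how cyano would read elsewhere on this ring.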